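A few compounds are considered here, and "the series" means these few. Any claim that something is new, unique, unknown or untested is made for them only; others in the source may bear on it.

Measured so far in an assay on CHO cells for displacement of a labelled ligand from adenosine receptor A2b (Homo sapiens), read by scintillation counting, with a stated time of 75 min, in the presence of a further agent that is not named here; on this read-out lower numbers stand for stronger inhibition and higher numbers for weaker inhibition:
compound 1 `CCCn1c(=O)[nH]c2nc(-c3ccc(S(=O)(=O)N4CCN(c5ccc(Cl)cc5F)CC4)cc3)[nH]c2c1=O` gives 1.91 nM;
compound 2 `CCCn1c(=O)[nH]c2nc(-c3ccc(S(=O)(=O)N4CCN(C)CC4)cc3)[nH]c2c1=O` gives 48.2 nM;
compound 3 `CCCn1c(=O)[nH]c2nc(-c3ccc(S(=O)(=O)N4CCN(c5cccc(F)c5)CC4)cc3)[nH]c2c1=O` gives 0.632 nM.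

Compound 3 holds the lowest number of the three. The gap to compound 1 is modest, a 3.0-fold lower number from compound 1 to compound 3 (0.48 log units; beyond the scatter); the gap to compound 2 is large, a 76-fold lower number from compound 2 to compound 3 (1.88 log units; beyond the scatter). Both steps lie beyond the scatter, so compound 3 stands as the strongest inhibitor of the set on this read-out.

Compound 4 `CCCn1c(=O)[nH]c2nc(-c3ccc(S(=O)(=O)N4CCN(Cc5ccc(Br)c(F)c5)CC4)cc3)[nH]c2c1=O` is the unmeasured member. The change from compound 3 is 4-bromo-3-fluorobenzyl in place of 3-fluorophenyl on an amine nitrogen in a ring. Going by the values given here, two measured steps bear on this point of the structure. Replacing the aryl group on the ring nitrogen by methyl costs a great deal, a 25-fold higher number from compound 1 to compound 2 (1.40 log units; beyond the scatter) and a 76-fold lower number from compound 2 to compound 3 (1.88 log units; beyond the scatter), while exchanging one aryl for another shifts the number only modestly, a 3.0-fold lower number from compound 1 to compound 3 (0.48 log units; beyond the scatter). Among the compounds with values here, compound 4 keeps an aromatic ring at this position but carries it on a benzyl rather than directly on the nitrogen; no measured pair shows that exact change. The expectation is a step toward a higher number, of modest size, a 4.7-fold higher number from compound 3 to compound 4 (0.68 log units; beyond the scatter), well short of the loss seen with methyl. The estimate for compound 4 is 3 nM, with a range from 0.8 nM to 12 nM.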

Compound 4, inhibition constant: 0.473 nM
Estimate against measurement, compound 4: 6.3-fold (0.80 log units) above; the measured number lies below the stated range.
By their numbers in this assay, from the lowest: compounds 4 and 3 (each within the scatter of the next); then compound 1; then compound 2.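

In this assay, moving the aromatic ring from the ring nitrogen onto a benzyl does not separate the pair: a 1.3-fold lower number from compound 3 to compound 4 (0.13 log units; within the scatter) leaves compound 3 and compound 4 within the scatter of each other. The large step seen on replacing methyl holds for the benzyl as well, with a 100-fold lower number from compound 2 to compound 4 (2.01 log units; beyond the scatter) on this change, and the benzyl also keeps a modest margin over the 4-chloro-2-fluorophenyl group, with a 4.0-fold lower number from compound 1 to compound 4 (0.61 log units; beyond the scatter) at this position. No measured evidence accounts for these steps.

Going by these compounds, how much rests on the bromine and the fluorine remains open, and a plain benzyl would separate their share from that of the ring. Also open, on these data alone, is how a phenethyl group, a longer chain, or a carboxylic acid on the benzyl ring would read here.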